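Moving the pyridine nitrogen in a urea-linked side chain

The source may report more compounds than this note shows. Statements on the series, on what has been measured and on what is new or still open speak of the compounds shown alone.

Three compounds share one core. In a functional assay on LNCaP cells (Homo sapiens) for cytotoxicity (a higher number here means a weaker inhibitor, a lower number a stronger inhibitor), compound 1 `CN1CCN(Cc2cc3nc(-c4ccc(NC(=O)Nc5cccnc5)cc4)nc(N4CC5CCC(C4)O5)c3s2)CC1` gives 148 nM, compound 2 `CNC(=O)Nc1ccc(-c2nc(N3CC4CCC(C3)O4)c3sc(CN4CCN(S(C)(=O)=O)CC4)cc3n2)cc1` gives 120 nM, and compound 3 `O=C(Nc1ccc(-c2nc(N3CC4CCC(C3)O4)c3sccc3n2)cc1)Nc1cccnc1` gives 27 nM, the lowest of the three numbers. For the measured compounds named here, the single change measured so far, a 5.5-fold lower number from compound 1 to compound 3 (0.74 log units; beyond the scatter), concerns the group on the aromatic carbon of the core, not the urea end.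

Compound 4 `O=C(Nc1ccncc1)Nc1ccc(-c2nc(N3CC4CCC(C3)O4)c3sccc3n2)cc1` differs from compound 3 by pyridin-4-yl in place of pyridin-3-yl on an amide-type nitrogen. Going by the values given here, no measured step bears on this change; the one step known is of a different kind, so nothing here points to a shift in either direction. The number for compound 4 is therefore expected close to that of compound 3, with a 1.3-fold higher number from compound 3 to compound 4 (0.11 log units; within the scatter) likely inside the scatter. Compound 4 is estimated at 35 nM, within a range from 12 nM to 100 nM.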

Compound 4, half-maximal inhibitory concentration: 10 nM
Compound 4: the middle estimate sits 3.5-fold (0.54 log units) above what was measured, outside the stated range (below it).
By their numbers in this assay, from the lowest: compound 4; then compound 3; then compounds 2 and 1 (each within the scatter of the next).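

For the compounds shown here, until now, the only measured change lay on an aromatic carbon of the core. At the urea end, pyridin-4-yl in place of pyridin-3-yl on an amide-type nitrogen gives a 2.7-fold lower number from compound 3 to compound 4 (0.43 log units; beyond the scatter) in this assay even though the two compounds have the same atoms, so the position of the ring nitrogen alone changes the number. Nothing available explains this shift.

Open, from the compounds shown here alone, is how pyridin-2-yl or plain phenyl would behave on that nitrogen. Also open, going by these compounds, is whether pyridin-4-yl keeps its lower number with (4-methylpiperazin-1-yl)methyl on the core.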